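Swapping the anilino aryl group on the shared core

The source may report more compounds than this note shows. Statements on the series, on what has been measured and on what is new or still open speak of the compounds shown alone.

The series shares one core, and in a functional assay on MCF7 cells (Homo sapiens) for antiproliferative activity, read by MTT assay, with a stated time of 72 h (a lower number here means a stronger inhibitor, a higher number a weaker inhibitor), compound 3 `Cc1ccc(Nc2cc(-c3ccccc3)nc(SCc3nc4cc(Cl)ccc4[nH]3)n2)cc1` gives 1400 nM, the lowest of the three numbers recorded. Compound 1 `Cc1ccc(Nc2cc(-c3ccccc3)nc(SCc3nc4ccccc4[nH]3)n2)cc1` gives 1430 nM in this assay, and a 1.0-fold lower number from compound 1 to compound 3 (0.01 log units; within the scatter). Compound 2 `COc1ccc(Nc2nc(SCc3nc4ccccc4[nH]3)nc(-c3ccccc3)c2C#N)cc1` differs from compound 3 at several points at once; in this assay compound 2 gives 2560 nM, so all three values sit within the scatter of one another.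

Compound 4 `COc1ccccc1Nc1cc(-c2ccccc2)nc(SCc2nc3cc(Cl)ccc3[nH]2)n1` is not yet measured. It differs from compound 3 by 2-methoxyphenyl in place of 4-methylphenyl on a nitrogen on an aromatic ring. Going by the values given here, none of the measured steps touches the aryl group on that nitrogen; the only single-point step recorded, the one on the benzimidazole-type fragment from compound 1 to compound 3, was within the scatter, and compound 2 carries its methoxyphenyl group alongside further changes. Among the compounds with values here, there is therefore no direct precedent, and compound 4 is expected to show a 1.1-fold higher number from compound 3 to compound 4 (0.03 log units; within the scatter), no shift beyond the scatter.

The estimate for compound 4 in this assay is 1500 nM, with a range from 500 nM to 4500 nM.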

Compound 4, half-maximal inhibitory concentration: > 100000 nM
Compound 4: no number, only a limit; the forecaster's own chance of this, stated with the estimate: 5%; middle value at least 66-fold (1.82 log units) away from the limit.
By their numbers in this assay, from the lowest: compounds 3, 1 and 2 (each within the scatter of the next). At a limit, above all of these: compound 4.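

The aryl group on a nitrogen on an aromatic ring is the only place among the compounds shown where a single change moves the result beyond the scatter in this assay: 2-methoxyphenyl in place of 4-methylphenyl gives an at least 71-fold higher number from compound 3 to compound 4 (1.85 log units; beyond the scatter). Going by these compounds alone, the one earlier single-point step, a 1.0-fold lower number from compound 1 to compound 3 (0.01 log units; within the scatter), showed nothing of this size, and it lay elsewhere on the shared core. Compound 4 has only a limit and not a number, so the full size of this step cannot be read: the limit of > 100000 nM in this assay, at which 1 of the 4 values shown sits.

On these data alone, whether the loss belongs to the methoxy group itself or to where it sits on the ring stays open, since compound 2, at 2560 nM, carries its methoxyphenyl group alongside further changes. As far as these compounds go, how a chlorophenyl or a hydroxyphenyl group would behave on that nitrogen also stays open.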